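The source may hold more compounds than are shown below. What is called first, only, known or untested is meant among the compounds shown, and "the series" means these compounds.

Series to date in an assay on isolated protein for displacement of a labelled ligand from 5-hydroxytryptamine receptor 6 (Homo sapiens); a lower number here means a stronger inhibitor, a higher number a weaker inhibitor:
compound 1 `CNS(=O)(=O)NC[C@@H]1CCCc2cc(S(=O)(=O)c3cccc(F)c3)ccc21` gives 1 nM;
compound 2 `O=C(NC[C@@H]1CCCc2cc(S(=O)(=O)c3cccc(F)c3)ccc21)c1ccc[nH]1` gives 5.01 nM;
compound 3 `O=C(NC[C@@H]1CCCc2cc(S(=O)(=O)c3cccc(F)c3)ccc21)c1ncc[nH]1` gives 15.9 nM.

Compound 3 holds the highest number of the three, set apart by a 3.2-fold higher number from compound 2 to compound 3 (0.50 log units; beyond the scatter) and a 16-fold higher number from compound 1 to compound 3 (1.20 log units; beyond the scatter). Compound 4 `O=S(=O)(c1cccc(F)c1)c1ccc2c(c1)CCC[C@H]2CN1CC(O)C1` carries 3-hydroxyazetidin-1-yl in place of ((1H-imidazol-2-yl)carbonyl)amino on a saturated chain carbon bound to a saturated ring carbon. Within the data shown here, no measured step covers this exchange; the three known steps all vary the group on the amine nitrogen, with a 5.0-fold higher number from compound 1 to compound 2 (0.70 log units; beyond the scatter) the smallest and a 16-fold higher number from compound 1 to compound 3 (1.20 log units; beyond the scatter) the largest, so that position has moved the read-out over a wide span. With the amide removed altogether the direction is open; a modest fall in the number, back towards the region of compounds 1 and 2, is expected rather than a further rise. Compound 4 is therefore estimated at 8 nM, between 2 nM and 40 nM, which would mean a 2.0-fold lower number from compound 3 to compound 4 (0.30 log units; within the scatter).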

Compound 4, inhibition constant: 0.1 nM
For compound 4 the middle estimate is 80-fold (1.90 log units) above the measured one, and the stated range ends above it.
By their numbers in this assay, from the lowest: compound 4; then compound 1; then compound 2; then compound 3.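

At this saturated chain carbon, 3-hydroxyazetidin-1-yl lowers the number against all three amino groups it replaces: ((1H-imidazol-2-yl)carbonyl)amino (a 160-fold lower number from compound 3 to compound 4 (2.20 log units; beyond the scatter)), ((1H-pyrrol-2-yl)carbonyl)amino (a 50-fold lower number from compound 2 to compound 4 (1.70 log units; beyond the scatter)) and (methylsulfamoyl)amino (a 10-fold lower number from compound 1 to compound 4 (1.00 log units; beyond the scatter)). A carbonyl or sulfamoyl group on the amine nitrogen is therefore not needed for a low number here, and compound 4 stands lowest of the four. Nothing available explains the size of these steps.

From the compounds shown here alone, whether the hydroxyl or the four-membered ring carries the effect remains open. An unsubstituted azetidine or a piperidine on the same carbon would separate the two.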